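The compounds below may be only part of what the source reports. "The series", "measured", "known", "first", "only" and "open" are said of these compounds alone.

Compound 1 `CCOc1ccc(NC(=O)Nc2cccc(CNc3nccnc3Cl)c2)cc1`: in a functional assay on T-24 cells (Homo sapiens) for antiproliferative activity, read by MTT assay, with a stated time of 48 h (a higher number here means a weaker inhibitor, a lower number a stronger inhibitor), compound 1 gives 9080 nM.
Compound 2 `O=C(Nc1cccc(CNc2nccnc2Cl)c1)Nc1ccccc1F`: in this assay compound 2 gives 7450 nM.
Compound 3 `O=C(Nc1cccc(CNc2nccnc2Cl)c1)Nc1ccc(Cl)cc1Cl`: in this assay compound 3 gives 5740 nM.

On the numbers alone compound 3 sits at the low end of the three, but a 1.6-fold lower number from compound 1 to compound 3 (0.20 log units; within the scatter) and a 1.3-fold lower number from compound 2 to compound 3 (0.11 log units; within the scatter) both lie within the scatter, so the three compounds cannot be told apart with confidence.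

Compound 4 `O=C(Nc1cccc(Cl)c1)Nc1cccc(CNc2nccnc2Cl)c1` is the next case. Relative to compound 3 the change is 3-chlorophenyl in place of 2,4-dichlorophenyl on an amide-type nitrogen. Among the compounds with values here, every measured step so far swaps the aryl group on that same amide-type nitrogen: a 1.2-fold lower number from compound 1 to compound 2 (0.09 log units; within the scatter), a 1.6-fold lower number from compound 1 to compound 3 (0.20 log units; within the scatter) and a 1.3-fold lower number from compound 2 to compound 3 (0.11 log units; within the scatter), all within the scatter. Three different aryl groups at this position have therefore given numbers that are indistinguishable, and a fourth aryl group is expected to behave the same way, with no step beyond the scatter, a 1.1-fold higher number from compound 3 to compound 4 (0.05 log units; within the scatter). For compound 4 the expected value in this assay is 6500 nM, with a range from 3000 nM to 14000 nM.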

Compound 4, half-maximal inhibitory concentration: 6810 nM
Estimate against measurement, compound 4: 1.0-fold (0.02 log units) below, within the range that was stated.
By their numbers in this assay, from the lowest: compounds 3, 4, 2 and 1 (each within the scatter of the next).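

Compound 4 carries one chlorine on its phenyl ring where compound 3 carries two, and in this assay this gives a 1.2-fold higher number from compound 3 to compound 4 (0.07 log units; within the scatter), so among these two compounds neither the number of chlorines nor their placing can be seen to matter. Against the fluorine- and ethoxy-bearing rings the picture is the same, with a 1.1-fold lower number from compound 2 to compound 4 (0.04 log units; within the scatter) and a 1.3-fold lower number from compound 1 to compound 4 (0.12 log units; within the scatter), so four different aryl groups on this amide-type nitrogen now give numbers that cannot be told apart. Nothing measured here offers an explanation for this flat result.

Still open, from the compounds shown here alone, is whether a different kind of group on this nitrogen, such as a phenyl ring bearing a carboxylic acid or an amine, would move the number beyond the scatter. Also open, going by these compounds, is what a change elsewhere in the shared core would do.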